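The source may report more compounds than this note shows. Statements on the series, on what has been measured and on what is new or still open speak of the compounds shown alone.

Notes on the series. The antiproliferative read-out is a functional assay on KB cells (Homo sapiens) for antiproliferative activity; on this read-out lower numbers stand for stronger inhibition and higher numbers for weaker inhibition. Compound 1 `CSc1nc2cnsc2n1[C@H]1C[C@H](O)[C@@H](CO)O1` in this assay gives only a limit, > 100000 nM. Compound 2 `Cc1nsc2c1ncn2[C@@H]1O[C@H](CO)[C@@H](O)[C@@H]1O` also gives a limit, > 100000 nM. Compound 3 `CSc1nc2c(C)nsc2n1[C@@H]1O[C@H](CO)[C@@H](O)[C@@H]1O` likewise gives a limit, > 100000 nM. For the measured compounds named here, the one step between measured compounds, a step that the two limits leave unreadable from compound 2 to compound 3, methylsulfanyl in place of hydrogen on an aromatic carbon, cannot be read in size because both of its ends are limits; what is known is summed up by the limit of > 100000 nM in this assay, at which 3 of the 3 values shown sit. Compound 3 therefore stands at the limit together with the two other values, and no number is known for any of the three.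

Compound 4 `CSc1nc2cnsc2n1[C@@H]1O[C@H](CO)[C@@H](O)[C@@H]1O` differs from compound 3 in one place: hydrogen in place of methyl on an aromatic carbon. Going by the values given here, no measured step has a readable size that bears on this change, so nothing points to a move away from the limit. The step that the limit leaves unreadable from compound 3 to compound 4 is expected to be nil beyond the scatter, because the limit of > 100000 nM in this assay, at which 3 of the 3 values shown sit, gathers every value at the limit. Compound 4 is expected to give 150000 nM in this assay, with a range from 60000 nM to 500000 nM.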

Compound 4, half-maximal inhibitory concentration: > 100000 nM
Compound 4 gave a limit, no number; the forecaster's own chance of this, stated with the estimate: 85%; the middle value lies beyond the limit too.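

Compound 4 adds no readable step: its steps from compound 3 and from compound 1 each join two limits, so neither size can be read. Left open in this assay is whether the methyl or hydroxy change has any effect, and how the four compounds compare: the limit of > 100000 nM in this assay, at which 4 of the 4 values shown sit.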